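The source may report more compounds than this note shows. Statements on the series, on what has been measured and on what is new or still open speak of the compounds shown alone.

Compounds measured in an assay on membranes from HeLa cells for displacement of a labelled ligand from adenosine receptor A3 (Homo sapiens), read by scintillation counting, with a stated time of 180 min, tested at 1 uM; on this read-out higher numbers stand for more inhibition at the one concentration tested (going by the name of the read-out) and lower numbers for less inhibition:
- compound 1 `CCCC(=O)C1=C(C)NC(=O)NC1c1ccco1` gives 1%
- compound 2 `CCCC(=O)C1=C(C)NC(=O)NC1c1cccs1` gives 2%
- compound 3 `CCCC(=O)C1=C(C)NC(=O)NC1c1ccsc1` gives 1%

Compound 3 stands level with compound 1 at the digits shown, the two of them together the lowest of the three numbers, and compound 2 sits only a single point away from either. All three comparisons fall inside the usual scatter: no change at the digits printed from compound 1 to compound 3 (within the scatter), a number 1 percentage points higher from compound 1 to compound 2 (within the scatter) and a number 1 percentage points lower from compound 2 to compound 3 (within the scatter). In other words, swapping furan-2-yl, thiophen-2-yl and thiophen-3-yl on the saturated ring carbon has left the read-out flat, and every one of the three compounds gives a low number at the tested concentration.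

Compound 4 `CCNC(=O)C1=C(C)NC(=O)NC1c1ccsc1` is the next step from compound 3. It differs by ethylamino in place of propyl on a carbonyl carbon. None of the three measured steps bears on this position: each of them alters the aromatic ring on the saturated ring carbon and leaves the carbonyl carbon and its propyl untouched. Going by the values given here, there is therefore no measured precedent for the change, only the observation that the core, however decorated so far, has given uniformly low numbers. Among the compounds with values here, with no step to lean on, the expectation for compound 4 is a step of a number 1 percentage points higher from compound 3 to compound 4 (within the scatter), that is, nothing beyond the scatter. Compound 4 is accordingly estimated at 2% in this assay, with a range from -8% to 12%.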

Compound 4, a percentage reported as inhibition, at one concentration (the size of the read-out at that concentration, not a potency): 1%
For compound 4 the middle estimate is 1 percentage points above the measured one; the range from low to high includes it.
By their numbers in this assay, from the lowest: compounds 1, 3, 4 and 2 (each within the scatter of the next).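

Of the steps shown, this is the only one at the carbonyl carbon whose other neighbour is the double-bonded ring carbon, and in this assay, ethylamino in place of propyl gives no change at the digits printed from compound 3 to compound 4 (within the scatter). The flat read-out seen for the aromatic ring swaps on the saturated ring carbon therefore also holds for this second place, at least for this one pair: exchanging propylcarbonyl for ethylcarbamoyl, which adds 1 hydrogen-bond donor and puts a nitrogen in the chain, does not lift the number at the one concentration tested. Nothing available gives a reason for this outcome.

Going by these compounds, it remains open whether a longer chain such as hexyl, a benzylamino group or a carboxylic acid on that carbonyl carbon would move the number beyond the scatter, and whether a phenyl group on the saturated ring carbon would do so. On these data alone, with all four compounds giving low numbers, it is also open whether either place would matter in a compound that gives a clearly higher number on this read-out.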